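Trimming a Methyl From the Side Chain of Compound 2

The source may report more compounds than this note shows. Statements on the series, on what has been measured and on what is new or still open speak of the compounds shown alone.

Compound 2 `CC(C)(C)CC#Cc1cc2ncnc(Nc3ccc(OCc4cccc(F)c4)c(Cl)c3)c2s1` gives, in an ADME assay on NIH3T3 cells (Mus musculus) for cytotoxicity (on this read-out lower numbers stand for higher toxicity in this test and higher numbers for lower toxicity in this test), > 50 uM, which is a limit of the assay rather than a number. Compound 1 `CN1CCN(CC#Cc2cc3ncnc(Nc4ccc(OCc5cccc(F)c5)c(Cl)c4)c3s2)CC1` gives 4.8 uM. Compound 3 `COCC#Cc1cc2ncnc(Nc3ccc(OCc4cccc(F)c4)c(Cl)c3)c2s1` gives > 50 uM, again a limit. The step of an at least 10-fold higher number from compound 1 to compound 2 (1.01 log units; beyond the scatter) and the step of an at least 10-fold higher number from compound 1 to compound 3 (1.01 log units; beyond the scatter) were both large, whereas the step that the two limits leave unreadable from compound 2 to compound 3 cannot be read. Compound 4 `CC(C)CC#Cc1cc2ncnc(Nc3ccc(OCc4cccc(F)c4)c(Cl)c3)c2s1` differs from compound 2 by hydrogen in place of methyl on a saturated chain carbon bound to three saturated chain carbons. Both readable steps replaced a 4-methylpiperazin-1-yl group, so they say little about removing one methyl. Compound 2 sits at the limit of > 50 uM in this assay, at which 2 of the 3 values shown sit. For compound 4 no step beyond the scatter is expected, a step that the limit leaves unreadable from compound 2 to compound 4, giving an estimate of 60 uM between 25 uM and 150 uM.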

Compound 4, half-maximal toxic concentration: > 50 uM
Compound 4 gave a limit, no number; the forecaster's own chance of this, stated with the estimate: 70%; the middle value is on the limit's open side.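

In this assay, compound 4 also ends at a limit of the assay rather than a number: the limit of > 50 uM in this assay, at which 3 of the 4 values shown sit.

The steps among compound 2, compound 3 and compound 4 cannot be read, so removing the methyl shows no measurable change. Isopropyl in place of 4-methylpiperazin-1-yl gives an at least 10-fold higher number from compound 1 to compound 4 (1.01 log units; beyond the scatter), making isopropyl the third group at this place to reach the limit, while compound 1 alone gives a number.

On these data alone, how far these three compounds lie beyond the limit stays open. So does whether a dimethylamino group or a carboxylic acid at this place would give a number.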